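Bromo substitution on the benzyl amide of compound 1

The source may hold more compounds than are shown below. What is called first, only, known or untested is meant among the compounds shown, and "the series" means these compounds.

Compound 1 `CN(Cc1ccccc1)C(=O)c1cc2c(Cc3ccccc3)n[nH]c2cc1O` is the reference point of this small set. Within the data shown here, in a functional assay on A2780 cells (Homo sapiens) for antiproliferative activity, read by resazurin assay, with a stated time of 72 h (a lower number here means a stronger inhibitor, a higher number a weaker inhibitor), compound 1 gives 980 nM, the lowest of the three numbers measured so far. Compound 2 `CN(C(=O)c1cc2c(Cc3ccccc3)n[nH]c2cc1O)c1ccco1` gives 2500 nM in this assay, and compound 3 `Cc1ccccc1CN(C)C(=O)c1cc2c(Cc3ccccc3)n[nH]c2cc1O` gives 4400 nM. The two measured variations both raise the number: a 2.6-fold higher number from compound 1 to compound 2 (0.41 log units; beyond the scatter) and a 4.5-fold higher number from compound 1 to compound 3 (0.65 log units; beyond the scatter), whereas the comparison a 1.8-fold higher number from compound 2 to compound 3 (0.25 log units; within the scatter) does not separate compounds 2 and 3.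

Compound 4 `CN(Cc1cccc(Br)c1)C(=O)c1cc2c(Cc3ccccc3)n[nH]c2cc1O` differs from compound 1 only in the benzyl part of the amide: bromo in place of hydrogen on an aromatic carbon. Among the measured compounds shown here, the step that bears most directly on it is the one from compound 1 to compound 3, where a single small substituent on the same ring was enough for a 4.5-fold higher number from compound 1 to compound 3 (0.65 log units; beyond the scatter). The bromo of compound 4 sits on a different carbon, meta to a large group, so that step is a guide to the kind of change rather than a firm measure of its size. A modest rise in the number is therefore expected rather than a fall, likely smaller than or similar to that seen for compound 3.

Compound 4 is expected to give 2000 nM in this assay, within a range of 900 nM to 4500 nM. This estimate corresponds to an expected step of a 2.0-fold higher number from compound 1 to compound 4 (0.31 log units; beyond the scatter).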

Compound 4, half-maximal inhibitory concentration: 7100 nM
Estimate against measurement, compound 4: 3.6-fold (0.55 log units) below, and the stated range ends below it.
By their numbers in this assay, from the lowest: compound 1; then compounds 2, 3 and 4 (each within the scatter of the next, the first and the last beyond it).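

In this assay bromo on the benzyl ring of the amide raises the number with a 7.2-fold higher number from compound 1 to compound 4 (0.86 log units; beyond the scatter) and so extends what the methyl of compound 3 suggested: both ring-substituted benzyl amides, compounds 3 and 4, now stand beyond the scatter from compound 1, and the unsubstituted benzyl of compound 1 keeps the lowest number of the set. The comparison a 1.6-fold higher number from compound 3 to compound 4 (0.21 log units; within the scatter) does not separate 3-bromobenzyl from 2-methylbenzyl, so these two substitutions cannot be ranked against each other, whereas a 2.8-fold higher number from compound 2 to compound 4 (0.45 log units; beyond the scatter) does set the 3-bromobenzyl amide apart from the furan-2-yl amide, even though compounds 2 and 3 remain unseparated. No measurement at hand accounts for the higher numbers of the substituted rings.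

Going by these compounds, whether fluoro or methoxy on the same ring carbon as the bromo of compound 4 would behave as bromo does remains open. So does whether an amine or a carboxylic acid on the benzyl ring, or a longer chain between the amide nitrogen and the ring, would bring the number back towards that of compound 1.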